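Moving a fluorine on the aryl group: what to expect

This account rests on a few compounds, and the source may have more. Where it says the series, first, only, none or still open, it means among the compounds named here.

Within the data shown here, in a functional assay on CHO cells for agonist activity at metabotropic glutamate receptor 2 (Homo sapiens), read by scintillation counting and GTPgammaS binding, with a stated time of 30 min (on this read-out higher numbers stand for larger maximal responses and lower numbers for smaller maximal responses), compound 1 `COc1ccc(F)cc1C1CCN(c2ccn3c(CC4CC4)nnc3c2Cl)CC1` gives 283%, and compound 2 `COc1c(C2CCN(c3ccn4c(CC5CC5)nnc4c3Cl)CC2)ccc(F)c1F` gives 342%, the higher of the two values; the only measured step is a number 59 percentage points higher from compound 1 to compound 2 (beyond the scatter). Compound 3 `COc1c(F)ccc(F)c1C1CCN(c2ccn3c(CC4CC4)nnc3c2Cl)CC1` differs from compound 2 by 3,6-difluoro-2-methoxyphenyl in place of 3,4-difluoro-2-methoxyphenyl on a saturated ring carbon. That one step shows a rearranged fluorine pattern changing the response by a large amount, but it does not tell which way another rearrangement goes, so the expectation for compound 3 is a step of a number 42 percentage points lower from compound 2 to compound 3 (beyond the scatter) that could fall either side within a broad band, and compound 3 is estimated at 300% with a range from 210% to 400%.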

Compound 3, largest response reached (Emax), in percent of the reference or control that the assay uses: 282%
Estimate against measurement, compound 3: 18 percentage points above, and the stated range covers the measured number.
By their numbers in this assay, from the lowest: compounds 3 and 1 (each within the scatter of the next); then compound 2.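

In this assay the same atoms, arranged as 3,6-difluoro-2-methoxyphenyl rather than 3,4-difluoro-2-methoxyphenyl, give a number 60 percentage points lower from compound 2 to compound 3 (beyond the scatter) so the response depends on where the fluorines sit, not only on which atoms are present. Against 5-fluoro-2-methoxyphenyl, the new group gives a number 1 percentage points lower from compound 1 to compound 3 (within the scatter) so an added fluorine does not by itself raise the response. Nothing measured here gives a reason for these differences. On these data alone, it remains open how a nitrile in place of a fluorine, or an ethoxy group in place of the methoxy, would change the response.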